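The compounds below may be only part of what the source reports. "The series", "measured", "known", "first", "only" and "open" are said of these compounds alone.

Three measured compounds anchor this account. Compound 1 `COc1ccc(Nc2nc3ccccc3nc2S(=O)(=O)c2ccccc2)cc1` gives 1510 nM in a functional assay on PC-3 cells (Homo sapiens) for cytotoxicity, read by MTT assay, with a stated time of 72 h; a lower number here means a stronger inhibitor, a higher number a weaker inhibitor. Compound 2 `COc1ccc(Nc2nc3ccccc3nc2S(=O)(=O)c2ccc(OC)cc2)cc1` differs from it by methoxy in place of hydrogen on an aromatic carbon; in this assay compound 2 gives 8710 nM, and the step of a 5.8-fold higher number from compound 1 to compound 2 (0.76 log units; beyond the scatter) lies beyond the scatter. Compound 3 `COc1ccc(S(=O)(=O)c2nc3ccccc3nc2Nc2cc(OC)cc(OC)c2)cc1` carries a 3,5-dimethoxyphenyl in place of the 4-methoxyphenyl on the nitrogen; in this assay compound 3 gives 6220 nM, and the step of a 1.4-fold lower number from compound 2 to compound 3 (0.15 log units; within the scatter) stays within the scatter, so compound 2 and compound 3 are not separated here. The difference between the core of compound 1 and the core of compound 3 is not broken down here.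

Compound 4 `COc1ccc(S(=O)(=O)c2nc3ccccc3nc2Nc2cc(OC)c(OC)c(OC)c2)cc1` is not yet measured. Its change from compound 3 is methoxy in place of hydrogen on an aromatic carbon. This is the same kind of change as that from compound 1 to compound 2, not the same: in compound 2 the entering methoxy sits para to a large group, while in compound 4 it sits ortho to two methoxy groups and para to a large group, on a different ring of the molecule. Because the earlier step of a 5.8-fold higher number from compound 1 to compound 2 (0.76 log units; beyond the scatter) ran toward a weaker inhibitor, compound 4 is expected to give a 1.4-fold higher number from compound 3 to compound 4 (0.16 log units; within the scatter) in this assay, a smaller move than the earlier one since the surroundings of the place differ. In this assay compound 4 is therefore estimated at 9000 nM, expected to fall between 3500 nM and 25000 nM.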

Compound 4, half-maximal inhibitory concentration: 7850 nM
Estimate against measurement, compound 4: 1.1-fold (0.06 log units) above, within the range that was stated.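

In this assay, the methoxy entering ortho to two methoxy groups and para to a large group gives a 1.3-fold higher number from compound 3 to compound 4 (0.10 log units; within the scatter), so compound 3 and compound 4 are not separated. The same change therefore does not carry over at the same size from one core to the other, since the clear loss seen on the core of compound 1 does not appear on the core of compound 3: the same change on two cores in this assay, a 5.8-fold higher number (0.76 log units; beyond the scatter) from compound 1 to compound 2 and a 1.3-fold higher number (0.10 log units; within the scatter) from compound 3 to compound 4, 4.6-fold (0.66 log units) apart, beyond the scatter of two such steps. This shows that, within these two pairs, the size of the step depends on where the change is made, but it does not show which difference matters, since the two steps differ both in the core and in the ring that takes the methoxy, and two steps give no rule for any other compound in the series.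

Going by these compounds, it remains open whether the methoxy would have the same effect on the other ring of compound 3, which would separate the role of the ring from that of the surrounding groups. On these data alone, it is also open whether an amine, a carboxylic acid or a longer alkoxy chain at the place filled in compound 4 would leave the number as unmoved as the methoxy does.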